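This account rests on a few compounds, and the source may have more. Where it says the series, first, only, none or still open, it means among the compounds named here.

Measured compounds:
Compound 1, `COc1ccccc1-n1nncc1CN1C(=O)C2(C(C#N)=C(N)Oc3c(N)cc4nc5ccccc5nc4c32)c2ccccc21`: in an ADME assay on HUVEC cells (Homo sapiens) for antiproliferative activity, read by MTT assay, with a stated time of 48 h (on this read-out higher numbers stand for weaker inhibition and lower numbers for stronger inhibition), compound 1 gives only a limit, > 50000 nM.
Compound 2, `N#CC1=C(N)Oc2c(N)cc3nc4ccccc4nc3c2C12C(=O)N(Cc1cnnn1-c1ccc(Cl)cc1Cl)c1ccccc12`: in this assay compound 2 likewise gives only a limit, > 50000 nM.

For the measured compounds named here, compound 2 thus stands at the limit of this assay, and the one further value shown, that of compound 1, is a limit too (the limit of > 50000 nM in this assay, at which 2 of the 2 values shown sit). Going by the values given here, the single step measured, a step that the two limits leave unreadable from compound 1 to compound 2, is unreadable with both ends sitting at limits, and it is the only step that bears on the present change.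

Compound 3, `N#CC1=C(N)Oc2c(N)cc3nc4ccccc4nc3c2C12C(=O)N(Cc1cnnn1-c1c(Cl)cc(Cl)cc1Cl)c1ccccc12`, differs from compound 2 by chloro in place of hydrogen on an aromatic carbon.

Among the compounds with values here, no measured step supplies a readable size, so no direction can be assigned from the data; the two limits of compound 1 and compound 2 point to compound 3 being reported at the limit of this assay as well. The step expected is a step that the limit leaves unreadable from compound 2 to compound 3, within the scatter in either direction. For compound 3 the estimate is 80000 nM, in a range from 30000 nM to 300000 nM, most probably returned as a limit rather than a number.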

Compound 3, half-maximal inhibitory concentration: 18300 nM
The estimate for compound 3 lay 4.4-fold (0.64 log units) above the measured number; measured number below the stated range.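

Chloro in place of hydrogen on an aromatic carbon, ortho to a large group and meta to two chloro groups, moves the series off the limit of this assay and gives its first readable change at this position: an at least 2.7-fold lower number from compound 2 to compound 3 (0.43 log units; beyond the scatter). The 2,4,6-trichlorophenyl group also reads against the 2-methoxyphenyl group on the same aromatic nitrogen, with an at least 2.7-fold lower number from compound 1 to compound 3 (0.43 log units; beyond the scatter), so this position can affect the read-out on the shared core, at least in compound 3. Both sizes are only lower bounds, and the true size of each step remains unknown, because each starts from a limit: the limit of > 50000 nM in this assay, at which 2 of the 3 values shown sit.

The step between compound 1 and compound 2 cannot be read, so these compounds do not show how 2,4-dichlorophenyl compares with 2-methoxyphenyl. They also leave open whether the lower number is specific to chloro at this place or would also follow from a methyl group, a methoxy group or an amine there, and whether 2,6-dichlorophenyl would leave the limit without the remaining chloro group.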